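The source may hold more compounds than are shown below. What is called first, only, known or untested is meant among the compounds shown, and "the series" means these compounds.

Of the compounds shown here, two have so far been measured in an ADME assay (liver) for metabolic stability, with Liver microsome (Rattus norvegicus) as the target, read by LC-MS, using microsomes and NADPH, with stated times of 5 min and 60 min, tested at 4 uM; a higher number here means that more of the compound is left, a lower number that less of the compound is left. Going by the values given here, compound 2 (`Cc1c(OCCCCOc2ccc(F)c(C(=O)O)c2)ccc(C(=O)C(C)C)c1O`) gives 60% there and compound 1 (`Cc1c(OCCCCOc2ccc(C(=O)O)cc2F)ccc(C(=O)CC(C)C)c1O`) gives 57% there, so the two numbers lie within the usual scatter of each other and compound 2 stands level with the only other measured compound.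

Compound 3 (`Cc1c(OCCCCOc2ccc(F)c(C(=O)O)c2)ccc(C(=O)CC(C)C)c1O`) has not yet been measured. The change from compound 2 to compound 3 is isobutyl in place of isopropyl on a carbonyl carbon and amounts to isobutyl in place of isopropyl on a carbonyl carbon. Among the compounds with values here, no pair of measured compounds differs in one place only, so the data hold no direct reading of this change. The expectation in this assay is therefore no step beyond the scatter, in either direction. Within the data shown here, the only support is that compound 1 at 57% and compound 2 at 60% lie within the scatter of each other. The expected a number 3 percentage points lower from compound 2 to compound 3 (within the scatter) is accordingly small. Compound 3 is estimated at 57% with an expected range from 45% to 69% in this measurement.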

Compound 3, percent of the compound remaining: 59%
Beside the measured number, compound 3's estimate is 2 percentage points below it; the measured number falls inside the stated range.
By their numbers in this assay, from the lowest: compounds 1, 3 and 2 (each within the scatter of the next).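

In this assay, going by these compounds alone, isobutyl in place of isopropyl on a carbonyl carbon gives a number 1 percentage points lower from compound 2 to compound 3 (within the scatter) and so can now be read directly, which no earlier pair allowed. Compound 3 also opens a second direct reading at the other end of the molecule: 3-carboxy-4-fluorophenyl in place of 4-carboxy-2-fluorophenyl on an oxygen on a saturated carbon gives a number 2 percentage points higher from compound 1 to compound 3 (within the scatter) and thus shows that, in these two pairs, neither single change takes the percent of compound remaining beyond the scatter. Nothing available here bears on the reason for this result.

The compounds shown leave open whether the carbonyl carbon tolerates larger departures from isopropyl and isobutyl, such as a longer chain like n-hexyl or a ring like cyclohexyl, since both groups read so far are short branched alkyl chains. They also leave open what happens at the other end when the carboxylic acid gives way to a tetrazole or a primary amide, or when the fluorine gives way to chlorine, as every compound shown carries a fluorinated benzoic acid.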